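Aryl hydrazone variation on the shared core, paw edema read-out

This account rests on a few compounds, and the source may have more. Where it says the series, first, only, none or still open, it means among the compounds named here.

Compound 2 `O=C(N/N=C/c1ccc(O)cc1)c1cccnc1Nc1cccc(C(F)(F)F)c1` gives 61.6% in a functional assay on the whole organism (strain Wistar) for inhibition, with Rattus norvegicus as the target, read by paw edema, with a stated time of 4 h, at a dose of 10 mg/kg by the intraperitoneal route (on this read-out higher numbers stand for more inhibition at the one dose given (going by the name of the read-out) and lower numbers for less inhibition), the highest of the three numbers. Compound 1 `O=C(N/N=C/c1cccc(Cl)c1)c1cccnc1Nc1cccc(C(F)(F)F)c1` gives 40.4%, and compound 3 `COc1cc(/C=N/NC(=O)c2cccnc2Nc2cccc(C(F)(F)F)c2)cc(OC)c1OC` gives 28.6%. Within the data shown here, the one step at this position so far, a number 21.2 percentage points higher from compound 1 to compound 2 (beyond the scatter), is the only one that bears on the next compound. Compound 4 `O=C(N/N=C/c1ccncc1)c1cccnc1Nc1cccc(C(F)(F)F)c1` differs from compound 2 by pyridin-4-yl in place of 4-hydroxyphenyl on a carbon with a double bond to nitrogen. Pyridin-4-yl carries no hydrogen-bond donor, so it does not repeat what 4-hydroxyphenyl brought, and the earlier step gives no read on this group itself. A step downward from compound 2, smaller than the earlier step, is expected: a number 15.6 percentage points lower from compound 2 to compound 4 (beyond the scatter). Compound 4 is therefore estimated at 46%, within 30% to 62%.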

Compound 4, a percentage reported as inhibition, in the whole organism at one dose (the size of the read-out at that dose, not a potency): 45.9%
Estimate against measurement, compound 4: 0.1 percentage points above, within the range that was stated.
By their numbers in this assay, from the lowest: compound 3; then compounds 1 and 4 (each within the scatter of the next); then compound 2.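

In this assay, a donor-free pyridin-4-yl in place of 4-hydroxyphenyl on the carbon with a double bond to nitrogen gives a number 15.7 percentage points lower from compound 2 to compound 4 (beyond the scatter), so the aromatic ring and acceptor count alone do not retain the response of compound 2. At the same place, a number 5.5 percentage points higher from compound 1 to compound 4 (within the scatter), which leaves pyridin-4-yl and 3-chlorophenyl unseparated on this read-out. No measurement at hand gives a reason for either step. Whether a phenyl ring bearing an amine or a carboxylic acid matches 4-hydroxyphenyl stays open, as does the response of these compounds at other doses.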